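This account rests on a few compounds, and the source may have more. Where it says the series, first, only, none or still open, it means among the compounds named here.

Compound 1 `COC(=O)/C=C/C1=CC[C@H]2C(C)(C)CCC[C@]2(C)[C@H]1C=O` is one of two measured compounds here. In a functional assay on Hs 683 cells (Homo sapiens) for inhibition, read by MTT assay, with a stated time of 72 h (on this read-out higher numbers stand for weaker inhibition of growth and lower numbers for stronger inhibition of growth), compound 1 gives 24000 nM, the lowest of the two numbers. Compound 2 `CC1(C)CCC[C@]2(C)[C@@H](C=O)C(/C=C/C(=O)OCc3ccccc3)=CC[C@@H]12` gives 31000 nM, and the step of a 1.3-fold higher number from compound 1 to compound 2 (0.11 log units; within the scatter) changes only the ester end of the chain. Compound 3 `COC(=O)/C=C/C=C/C1=CC[C@H]2C(C)(C)CCC[C@]2(C)[C@H]1C=O` differs from compound 1 elsewhere: 2-(methoxycarbonyl)ethenyl in place of methoxycarbonyl on a double-bonded chain carbon bound to a double-bonded chain carbon. Within the data shown here, the single measured step does not touch this part of the chain, so no measured step bears on it, and no move beyond the scatter is expected, no change at the digits printed from compound 1 to compound 3 (within the scatter). Compound 3 is therefore estimated at 24000 nM, within 8000 nM to 70000 nM.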

Compound 3, concentration for 50% growth inhibition: 12000 nM
Compound 3: the middle estimate sits 2.0-fold (0.30 log units) above what was measured; low and high end bracket the measured number.
By their numbers in this assay, from the lowest: compounds 3, 1 and 2 (each within the scatter of the next, the first and the last beyond it).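

Putting 2-(methoxycarbonyl)ethenyl in place of methoxycarbonyl gives a 2.0-fold lower number from compound 1 to compound 3 (0.30 log units; within the scatter) in this assay. The earlier step changed only the ester end, whereas this one shows that the chain itself can carry an added double bond and two more carbons with no move beyond the scatter. Nothing available explains this result.

On these data alone, what a still longer chain would do in this assay remains open. So does the effect of a carboxylic acid or an amine at the end of this chain.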